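The source may hold more compounds than are shown below. What is called first, only, known or untested is meant among the compounds shown, and "the series" means these compounds.

Compound 1 `N#Cc1cccc(Cn2cc(CNC3=C(Cl)C(=O)c4cccnc4C3=O)nn2)c1`: 4840 nM
Compound 2 `Cc1ccc(Cn2cc(CNC3=C(Cl)C(=O)c4cccnc4C3=O)nn2)cc1`: 4710 nM

Going by the values given here, in a functional assay on MCF7 cells (Homo sapiens) for antiproliferative activity, read by sulforhodamine B assay, with a stated time of 72 h (a lower number here means a stronger inhibitor, a higher number a weaker inhibitor), compound 2 stands level with compound 1, the only other compound measured. Compound 3 `N#Cc1ccccc1Cn1cc(CNC2=C(Cl)C(=O)c3cccnc3C2=O)nn1` carries 2-cyanophenyl in place of 4-methylphenyl on a saturated chain carbon bound to an aromatic nitrogen. Among the compounds with values here, one measured step bears on this change, at the same place: a 1.0-fold lower number from compound 1 to compound 2 (0.01 log units; within the scatter). Within the data shown here, no measured compound carries 2-cyanophenyl, so that step is thin evidence, but it points to no shift beyond the scatter in this assay. The expected result is a 1.0-fold lower number from compound 2 to compound 3 (0.02 log units; within the scatter). For compound 3 the estimated value is 4500 nM, with an expected range of 2200 nM to 9000 nM.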

Compound 3, half-maximal inhibitory concentration: 4700 nM
For compound 3 the middle estimate is 1.0-fold (0.02 log units) below the measured one; the measured number falls inside the stated range.
By their numbers in this assay, from the lowest: compounds 3, 2 and 1 (each within the scatter of the next).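

In this assay, 2-cyanophenyl in place of 4-methylphenyl gives a 1.0-fold lower number from compound 2 to compound 3 (0.00 log units; within the scatter), and 2-cyanophenyl in place of 3-cyanophenyl gives a 1.0-fold lower number from compound 1 to compound 3 (0.01 log units; within the scatter). At this position, then, the three substituted phenyl groups stand level, whether the nitrile is present or absent and in either of the two placements shown. Nothing available accounts for this flat result. The compounds shown leave open whether this level holds for a phenyl ring carrying an amine or a carboxylic acid. They also leave open what a longer chain would do at this place.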